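The source may report more compounds than this note shows. Statements on the series, on what has been measured and on what is new or still open speak of the compounds shown alone.

Measured compounds in hand:
compound 1, `COc1cc(CCc2cccc(Cl)c2Cl)cc(OC)c1O`, 4770 nM
compound 2, `COc1cc(CCc2ccccn2)cc(OC)c1O`, 4840 nM
compound 3, `COc1ccccc1CCc1cc(OC)c(O)c(OC)c1`, 2480 nM

All three numbers come from a functional assay on HepG2 cells (Homo sapiens) for antiproliferative activity, read by MTT assay, with a stated time of 72 h; a lower number here means a stronger inhibitor, a higher number a weaker inhibitor. The shared core carries a two-carbon saturated chain to a second aromatic ring, and the three compounds differ only in that second ring. Compound 2 gives the highest of the three numbers, but its gap to compound 1 is negligible and its gap to compound 3 also stays within the usual scatter, so no order of potency among compounds 1, 2 and 3 can be read from these values.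

Compound 4, `COc1cc(CCc2ccncc2)cc(OC)c1O`, has not yet been measured in this assay. It differs from compound 2 in one respect: pyridin-4-yl in place of pyridin-2-yl on a saturated chain carbon, two bonds along the chain from an aromatic carbon. Among the measured compounds shown here, no measured pair in this set shows this change, so there is no step of its kind to lean on; the only guide is that the three measured second rings, although quite different, all give numbers within the scatter of one another.

On that basis the step in this assay from compound 2 to compound 4 is expected to be small, in neither direction beyond the scatter, as a 1.1-fold lower number from compound 2 to compound 4 (0.03 log units; within the scatter). Compound 4 is expected to give about 4500 nM, with a range from 2000 nM to 10000 nM.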

Compound 4, half-maximal inhibitory concentration: 2170 nM
For compound 4 the middle estimate is 2.1-fold (0.32 log units) above the measured one; measured number inside the range.
By their numbers in this assay, from the lowest: compounds 4, 3, 1 and 2 (each within the scatter of the next, the first and the last beyond it).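

In this assay, among the compounds shown here, pyridin-4-yl in place of pyridin-2-yl on a saturated chain carbon, two bonds along the chain from an aromatic carbon, gives a 2.2-fold lower number from compound 2 to compound 4 (0.35 log units; beyond the scatter), a modest step and the only one so far. Compounds 1, 2 and 3, which carry quite different second rings, left no readable order, whereas this pair shares the same atoms joined differently, showing that the number at this position can shift with no change in the atoms present or in the counted donors and acceptors of the ring. Nothing on hand bears on what lies behind this step.

As far as these compounds go, it remains open whether pyridin-3-yl at the same place would fall with pyridin-2-yl, with pyridin-4-yl or elsewhere, and whether the step between the two pyridine rings would persist on a longer chain. From the compounds shown here alone, it is also open whether an amine or a carboxylic acid on the second ring would move the number further than this step, since compound 4 remains within the scatter of compounds 1 and 3.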